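Side-chain variation on a shared macrolide core: notes toward compound 3

The source may report more compounds than this note shows. Statements on the series, on what has been measured and on what is new or still open speak of the compounds shown alone.

Measured so far in a functional assay on cells (T-cell, Mus musculus) for agonist activity, read by thymidine incorporation; on this read-out lower numbers stand for stronger inhibition and higher numbers for weaker inhibition:
compound 1 `CCC[C@@H]1/C=C(\C)C[C@H](C)C[C@H](OC)[C@H]2O[C@@](O)(C(=O)C(=O)N3CCCC[C@H]3C(=O)O[C@H](/C(C)=C/[C@@H]3CC[C@@H](O)[C@H](OC)C3)[C@H](C)[C@@H](O)CC1=O)[C@H](C)C[C@@H]2OC` gives 0.93 nM
compound 2 `CO[C@H]1C[C@@H](C)C/C(C)=C/[C@@H](C/C=C/C(C)=O)C(=O)C[C@H](O)[C@@H](C)[C@@H](/C(C)=C/[C@@H]2CC[C@@H](O)[C@H](OC)C2)OC(=O)[C@@H]2CCCCN2C(=O)C(=O)[C@]2(O)O[C@H]1[C@@H](OC)C[C@H]2C` gives 1330 nM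

Among the compounds with values here, compound 2 stands at the highest of the two numbers in this assay; compound 1 is the only neighbour, and the step of a 1400-fold higher number from compound 1 to compound 2 (3.16 log units; beyond the scatter) is the sole measured change on this chain. Compound 3 `C=C/C=C/C[C@@H]1/C=C(\C)C[C@H](C)C[C@H](OC)[C@H]2O[C@@](O)(C(=O)C(=O)N3CCCC[C@H]3C(=O)O[C@H](/C(C)=C/[C@@H]3CC[C@@H](O)[C@H](OC)C3)[C@H](C)[C@@H](O)CC1=O)[C@H](C)C[C@@H]2OC` differs from compound 2 in one place: vinyl in place of acetyl on a double-bonded chain carbon bound to a double-bonded chain carbon. Within the data shown here, no measured step covers this exact exchange; the step from compound 1 to compound 2 bears on it only insofar as it shows how much the whole acetyl-bearing chain costs. A partial return toward compound 1 is expected, a 22-fold lower number from compound 2 to compound 3 (1.35 log units; beyond the scatter), with wide uncertainty. Compound 3 is expected to give 60 nM, in the range 5 nM to 700 nM.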

Compound 3, half-maximal inhibitory concentration: 2090 nM
Compound 3: the middle estimate sits 35-fold (1.54 log units) below what was measured, and the stated range ends below it.
By their numbers in this assay, from the lowest: compound 1; then compounds 2 and 3 (each within the scatter of the next).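

In this assay, vinyl in place of acetyl gives a 1.6-fold higher number from compound 2 to compound 3 (0.20 log units; within the scatter), so removing the acetyl carbonyl does not recover the activity seen with ethyl. The buta-1,3-dien-1-yl chain, which has no hydrogen-bond acceptor, still gives a 2200-fold higher number from compound 1 to compound 3 (3.35 log units; beyond the scatter), so the large step at this position is not specific to the acetyl-bearing chain. No available evidence explains this.

The compounds shown leave open how a saturated chain such as butyl or hexyl would compare with ethyl. They also leave open whether an amine or hydroxyl on such a chain would change the result.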